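A few compounds are considered here, and "the series" means these few. Any claim that something is new, unique, unknown or untested is made for them only; others in the source may bear on it.

Measured in a functional assay on OVCAR-3 cells (Homo sapiens) for antiproliferative activity, read by MTT assay, with a stated time of 24 h; a higher number here means a weaker inhibitor, a lower number a stronger inhibitor:
compound 1, `O=c1[nH]cc(S(=O)(=O)Nc2ccccc2-c2cn(-c3ccc(F)cc3)nn2)c(=O)[nH]1` — > 20000 nM, a limit of the assay rather than a number
compound 2, `O=c1[nH]cc(S(=O)(=O)Nc2cccc(-c3cn(-c4ccccc4F)nn3)c2)c(=O)[nH]1` — 12500 nM
compound 3, `Cc1cccc(-n2cc(-c3ccc(NS(=O)(=O)c4c[nH]c(=O)[nH]c4=O)cc3)nn2)c1` — 7490 nM

Compound 1 reaches only the limit of this assay, (the limit of > 20000 nM in this assay, at which 1 of the 3 values shown sits). Compound 2 and compound 3 both give numbers, and these two sit within the usual scatter of each other, so no order between them can be read; compound 3 simply holds one of the two numbers of the series. Compound 4, `O=c1[nH]cc(S(=O)(=O)Nc2ccc(-c3cn(-c4cccc(Cl)c4)nn3)cc2)c(=O)[nH]1`, has not been measured in this assay. It differs from compound 3 in one place: chloro in place of methyl on an aromatic carbon, the 3-methylphenyl becoming 3-chlorophenyl. Among the measured compounds shown here, no measured pair carries this change, so the step can only be guessed from the single reference point. The step is expected to be small and without a clear direction beyond the scatter, a 1.2-fold lower number from compound 3 to compound 4 (0.10 log units; within the scatter). Compound 4 is therefore estimated at 6000 nM, with a range from 2000 nM to 18000 nM.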

Compound 4, half-maximal inhibitory concentration: 2750 nM
For compound 4 the middle estimate is 2.2-fold (0.34 log units) above the measured one, and the stated range covers the measured number.
By their numbers in this assay, from the lowest: compound 4; then compounds 3 and 2 (each within the scatter of the next). At a limit, above all of these: compound 1.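

In this assay, among the compounds shown here, the exchange of methyl for chloro on an aromatic carbon, meta to a large group, gives a 2.7-fold lower number from compound 3 to compound 4 (0.44 log units; beyond the scatter) and is the first change that can be read beyond the scatter. For the compounds shown here, this position therefore responds to the exchange of one heavy atom, although the step is modest and rests on the single pair of 3-methylphenyl and 3-chlorophenyl. No measurement shown here accounts for the step.

Going by these compounds, whether the same exchange acts alike elsewhere on this ring remains open, as compound 1 and compound 2 differ from compound 4 in more than one place. On these data alone, how a methoxy, nitrile or trifluoromethyl group would read at this position also remains open.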